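Phenyl in Place of Fluorobenzyl on the Shared Core

The source may hold more compounds than are shown below. What is called first, only, known or untested is meant among the compounds shown, and "the series" means these compounds.

Compound 1 `O=C(O)c1ccccc1-c1ccc(CCc2ncc(Cc3ccccc3F)[nH]2)cc1` gives 177 nM in an in vitro functional assay on cells for agonist activity at Bombesin receptor subtype-3 (Homo sapiens), read by luminescence and calcium flux; a lower number here means that less compound is needed, a higher number that more compound is needed for the effect.
Compound 2 `O=C(O)c1ccccc1-c1ccc(CCc2ncc(Cc3ccc(F)cc3)[nH]2)cc1` gives 1600 nM in this assay.

For the measured compounds named here, compound 2 stands at the higher of the two numbers in this assay, and the only measured step, a 9.0-fold higher number from compound 1 to compound 2 (0.96 log units; beyond the scatter), concerns the position of the fluorine alone. Compound 3 `O=C(O)c1ccccc1-c1ccc(CCc2ncc(-c3ccccc3)[nH]2)cc1` carries a different change: phenyl in place of 4-fluorobenzyl on an aromatic carbon. Going by the values given here, no measured step covers loss of the chain carbon together with the fluorine, so the expectation rests on compound 2 with wide bounds. The expected step is a 1.3-fold lower number from compound 2 to compound 3 (0.12 log units; within the scatter). Compound 3 is estimated at 1200 nM, within 150 nM to 9000 nM.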

Compound 3, half-maximal effective concentration: 4950 nM
Beside the measured number, compound 3's estimate is 4.1-fold (0.62 log units) below it; measured number inside the range.
By their numbers in this assay, from the lowest: compound 1; then compound 2; then compound 3.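

In this assay, the change on this aromatic carbon matters beyond where the fluorine sits: phenyl in place of 4-fluorobenzyl gives a 3.1-fold higher number from compound 2 to compound 3 (0.49 log units; beyond the scatter) and phenyl in place of 2-fluorobenzyl gives a 28-fold higher number from compound 1 to compound 3 (1.45 log units; beyond the scatter). Among these three compounds, then, the phenyl of compound 3 goes with the highest number and the 2-fluorobenzyl of compound 1 with the lowest. Nothing available bears on why the numbers move this way. What the compounds shown leave open is how an unsubstituted benzyl would compare, which would separate the chain carbon from the fluorine. From the compounds shown here alone, a longer chain, such as 2-phenylethyl, also remains open at this position.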